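Fluoro on the anilide ring of a weak cytotoxic series

The source may hold more compounds than are shown below. What is called first, only, known or untested is meant among the compounds shown, and "the series" means these compounds.

Compound 1, `O=C(Nc1ccc(Oc2ccnc3[nH]ccc23)cc1)c1ccc(-c2ccc(Cl)cc2)cn1`, in a functional assay on A549 cells (Homo sapiens) for cytotoxicity, read by MTT assay, with a stated time of 72 h (a lower number here means a stronger inhibitor, a higher number a weaker inhibitor), gives > 10000 nM, a limit of the assay.
Compound 2, `Cc1ccc(-c2ccc(C(=O)Nc3ccc(Oc4ccnc5[nH]ccc45)cc3)nc2)cc1`, in this assay gives > 10000 nM, again a limit.
Compound 3, `CCc1ccc(-c2ccc(C(=O)Nc3ccc(Oc4ccnc5[nH]ccc45)cc3)nc2)cc1`, in this assay gives > 10000 nM, again a limit.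

Compound 2 therefore stands at the limit of > 10000 nM in this assay, at which 3 of the 3 values shown sit, a limit rather than a number. Compound 4, `Cc1ccc(-c2ccc(C(=O)Nc3ccc(Oc4ccnc5[nH]ccc45)c(F)c3)nc2)cc1`, differs from compound 2 by fluoro in place of hydrogen on an aromatic carbon, on an aromatic carbon of a six-membered aromatic ring of carbon only. No measured step changes this ring; the steps shown, a step that the two limits leave unreadable from compound 1 to compound 2, a step that the two limits leave unreadable from compound 1 to compound 3 and a step that the two limits leave unreadable from compound 2 to compound 3, all sit between limits and so give no readable size. Going by the values given here, they show only that three changes at the far end of the shared core left every value at the limit. For compound 4 the expected step is a step that the limit leaves unreadable from compound 2 to compound 4, most likely again a limit. Compound 4 is therefore estimated at 20000 nM, with a range of 5000 nM to 100000 nM.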

Compound 4, half-maximal inhibitory concentration: 2300 nM
Compound 4: the middle estimate sits 8.7-fold (0.94 log units) above what was measured; measured number below the stated range.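

Fluoro in place of hydrogen, on an aromatic carbon of a six-membered aromatic ring of carbon only, gives an at least 4.3-fold lower number from compound 2 to compound 4 (0.63 log units; beyond the scatter). The other steps cannot be read, and all of them lie at the far end of the shared core, so this is the only readable step among the compounds shown and the only one on this ring, a single added fluorine atom being enough to bring a value within the measurable range. Its size is only a floor, as the starting point, compound 2, stands at a limit and not at a number: the limit of > 10000 nM in this assay, at which 3 of the 4 values shown sit.

On these data alone, whether the same fluoro would also bring compound 1 or compound 3 off the limit stays open. So does whether chloro, methoxy or an amine at this position would give a similar step, a larger one or none.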